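The source may hold more compounds than are shown below. What is called first, only, known or untested is meant among the compounds shown, and "the series" means these compounds.

Compound 2, with the structure `Fc1cccc(-c2nn3c(CSc4ccccc4)nnc3s2)c1`, has the lower of the two measured numbers in an assay for inhibition of histone-lysine N-methyltransferase, H3 lysine-79 specific (Homo sapiens), with stated times of 15 min and 120 min, tested at 50 uM; a lower number here means less inhibition, a higher number more inhibition at the concentration tested (going by the name of the read-out): compound 2 gives 21%, the lowest of the two numbers shown. Its nearest neighbour is compound 1, with the structure `Fc1cccc(-c2nn3c(Cc4ccccc4)nnc3s2)c1`, which in this assay gives 33%. Among the measured compounds shown here, the single measured step, a number 12 percentage points lower from compound 1 to compound 2 (beyond the scatter), is therefore a modest drop in the number when the group on the saturated chain carbon is changed.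

Compound 3, with the structure `Fc1cccc(-c2nn3c(Cc4ccccc4F)nnc3s2)c1`, is the next compound in this line. It differs from compound 2 as follows: 2-fluorophenyl in place of phenylsulfanyl on a saturated chain carbon bound to an aromatic carbon. For the measured compounds named here, this change largely undoes the one step measured so far, since the group that entered from compound 1 to compound 2 now leaves again, and an aromatic ring returns to the chain carbon, carrying a fluorine this time. Going by the values given here, the only step that bears on it is a number 12 percentage points lower from compound 1 to compound 2 (beyond the scatter), so a rise of about the same size is expected, taking compound 3 roughly back to the level of compound 1. The expected step is a number 12 percentage points higher from compound 2 to compound 3 (beyond the scatter). Compound 3 is accordingly estimated at 33%, within the range 15% to 50%.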

Compound 3, a percentage reported as inhibition, at one concentration (the size of the read-out at that concentration, not a potency): 25%
Compound 3: the middle estimate sits 8 percentage points above what was measured, within the range that was stated.
By their numbers in this assay, from the lowest: compounds 2, 3 and 1 (each within the scatter of the next, the first and the last beyond it).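

In this assay, 2-fluorophenyl in place of phenylsulfanyl on the saturated chain carbon gives a number 4 percentage points higher from compound 2 to compound 3 (within the scatter), so this assay does not separate these two groups, although each brings an aromatic ring of carbon only and the same count of heavy atoms. Fluoro in place of hydrogen on an aromatic carbon gives a number 8 percentage points lower from compound 1 to compound 3 (within the scatter), so the fluorine makes no readable difference here, and compound 3 cannot be grouped with either compound 1 or compound 2, even though those two stand apart beyond the scatter. Nothing available explains these numbers or the difference between compound 1 and compound 2.

Every compound shown keeps an aromatic ring one chain carbon away from the shared core, so it remains open whether an amine, a carboxylic acid or a longer chain at this place would give a clearly different number. Each value is also a reading at one concentration, which leaves open how the potencies of these compounds compare.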